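Swapping a Trifluorinated Ring for an Isobutyl Chain

A few compounds are considered here, and "the series" means these few. Any claim that something is new, unique, unknown or untested is made for them only; others in the source may bear on it.

Compound 1 `CS(=O)(=O)Nc1ccc2c(c1)S(=O)(=O)N=C(C1=C(O)[C@@H]3[C@H]4CC[C@H](C4)[C@@H]3N(Cc3ccc(F)c(F)c3F)C1=O)N2` was tested in an in vitro ADME assay on microsomes from liver (Homo sapiens) for metabolic stability, tested at 1 uM; a higher number here means that the compound lasts longer, a lower number that the compound disappears faster. In this assay compound 1 gives > 1 h, which is a limit of the assay rather than a number. Compound 3 `CS(=O)(=O)Nc1ccc2c(c1)S(=O)(=O)N=C(C1=C(O)[C@@H]3[C@@H]4CC[C@@H](C4)[C@@H]3N(Cc3ccc(F)c(F)c3F)C1=O)N2` differs from compound 1 in that (the two compounds have the same atoms and bonds and differ only in configuration as drawn: 2 of 4 stereo elements differ; a stereocentre at a saturated ring carbon is drawn S in compound 1 and R in compound 3; a stereocentre at a saturated ring carbon is drawn R in compound 1 and S in compound 3). In this assay compound 3 also gives > 1 h, again a limit. The step that the two limits leave unreadable from compound 1 to compound 3 therefore cannot be read, because of the limit of > 1 h in this assay, at which 2 of the 3 values shown sit.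

Compound 2 `CC(C)CCN1C(=O)C(C2=NS(=O)(=O)c3cc(NS(C)(=O)=O)ccc3N2)=C(O)[C@@H]2[C@H]3CC[C@H](C3)[C@@H]21` carries the change (isobutyl in place of 2,3,4-trifluorophenyl on a saturated chain carbon bound to an amide-type nitrogen in a ring). In this assay compound 2 gives 0.617 h, and the step is an at least 1.6-fold lower number from compound 1 to compound 2 (0.20 log units; that floor lies within the scatter).

Compound 4 `CC(C)CCN1C(=O)C(C2=NS(=O)(=O)c3cc(NS(C)(=O)=O)ccc3N2)=C(O)[C@@H]2[C@@H]3CC[C@@H](C3)[C@@H]21` carries the same change on the core of compound 3, described as isobutyl in place of 2,3,4-trifluorophenyl on a saturated chain carbon bound to an amide-type nitrogen in a ring, at the same place. The expected step is an at least 1.6-fold lower number from compound 3 to compound 4 (0.22 log units; that floor lies within the scatter), resting on the measured step of an at least 1.6-fold lower number from compound 1 to compound 2 (0.20 log units; that floor lies within the scatter). Compound 4 is thus estimated at 0.6 h, expected between 0.3 h and 1.2 h.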

Compound 4, half-life: 0.3 h
Estimate against measurement, compound 4: 2.0-fold (0.30 log units) above; measured number inside the range.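

In this assay the swap from 2,3,4-trifluorobenzyl to isopentyl on the core of compound 3 gives an at least 3.3-fold lower number from compound 3 to compound 4 (0.52 log units; beyond the scatter), so on this core the change shortens the half-life beyond the usual scatter. With isopentyl on both cores, the drawn configuration alone gives a 2.1-fold lower number from compound 2 to compound 4 (0.31 log units; beyond the scatter), so the core does affect the half-life of the isopentyl compounds. Whether the change has the same size on both cores cannot be read, because only lower bounds on its size are available: the same change on two cores in this assay, an at least 1.6-fold lower number (0.20 log units; that floor lies within the scatter) from compound 1 to compound 2 and an at least 3.3-fold lower number (0.52 log units; beyond the scatter) from compound 3 to compound 4; the limit leaves it open whether they differ.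

On these data alone, how a longer chain, an amine or a carboxylic acid at this place would fare remains open. So does how far compound 1 and compound 3 lie beyond their limits.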